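The compounds below may be only part of what the source reports. "The series", "measured", "known", "first", "only" and "open" are said of these compounds alone.

Working notes on the series.

Compound 1 `COc1ccc(NC(=O)NCc2cnc3scc(-c4ccc(Br)cc4)n23)cc1` is the reference point. In an assay on isolated protein for inhibition of Indoleamine 2,3-dioxygenase 1 (Homo sapiens), with a stated time of 30 min (a lower number here means a stronger inhibitor, a higher number a weaker inhibitor), compound 1 gives 190 nM, the lowest of the two numbers recorded; the nearest measured neighbour is compound 3 `CCOC(=O)c1cnc2scc(-c3ccc(C)cc3)n12`, which in this assay gives 18000 nM, a gap far beyond the scatter. Compound 2 `CCOC(=O)c1cnc2scc(C3=CCCCC3)n12` reaches only the assay limit, > 100000 nM, in this assay. The limit line the limit of > 100000 nM in this assay, at which 1 of the 3 values shown sits, marks where that value sits. Within the data shown here, no two measured compounds differ in a single place, so no measured step is available.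

The next compound, compound 4 `O=C(NCc1cnc2scc(-c3ccc(Br)cc3)n12)Nc1ccccc1`, differs from compound 1 by hydrogen in place of methoxy on an aromatic carbon. With no measured step of this kind in the set, the expectation is a small change, if any, in this assay for compound 4, likely a slight weakening beyond nothing certain; the step from compound 1 to compound 4 is estimated at a 1.7-fold higher number from compound 1 to compound 4 (0.23 log units; within the scatter). Compound 4 is expected to give about 320 nM in this assay, within 110 nM to 950 nM.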

Compound 4, half-maximal inhibitory concentration: 220 nM
The estimate for compound 4 lay 1.5-fold (0.16 log units) above the measured number, and the stated range covers the measured number.
By their numbers in this assay, from the lowest: compounds 1 and 4 (each within the scatter of the next); then compound 3. At a limit, above all of these: compound 2.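

In this assay the series gains its first single-place comparison (a 1.2-fold higher number from compound 1 to compound 4 (0.06 log units; within the scatter)), the change being 4-methoxyphenyl to phenyl, para to a large group. The two compounds cannot be told apart at this position, so the methoxy is not required for the inhibition seen with compound 1, and the bare phenyl of compound 4 serves equally well in this assay. Nothing measured in the set bears on why this replacement leaves the two compounds indistinguishable.

Only hydrogen and methoxy are shown at this position, so it remains open how a chlorine, an amine or a carboxylic acid would read there. Compound 3 differs from compound 4 in more than one place, so the separate contributions of the ethyl ester and of the group on the other aromatic ring stay unresolved.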